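A few compounds are considered here, and "the series" means these few. Any claim that something is new, unique, unknown or untested is made for them only; others in the source may bear on it.

In a functional assay on cells (Homo sapiens) for inhibition (a lower number here means a stronger inhibitor, a higher number a weaker inhibitor), compound 1 `O=C(/C=C\N(O)c1ccccc1)c1ccc(F)cc1` is recorded only as a limit, > 10000 nM. Among the compounds with values here, compound 2 `CN(O)/C=C\C(=O)c1ccc(F)cc1` gives 5500 nM, the only true number so far. Compound 3 `O=C(/C=C\N(O)C1CCCCC1)c1ccc(F)cc1` departs from it by cyclohexyl in place of methyl on an amine nitrogen. Within the data shown here, one measured step bears on this change: an at least 1.8-fold lower number from compound 1 to compound 2 (0.25 log units; that floor lies within the scatter), with methyl in place of phenyl, a floor within the scatter that rests on (the limit of > 10000 nM in this assay, at which 1 of the 2 values shown sits). Compound 1 thus offers only a weak hint that a ring on this nitrogen gives a higher number in this assay. A modest rise is therefore expected, an estimated 1.6-fold higher number from compound 2 to compound 3 (0.21 log units; within the scatter). Compound 3 is expected at 9000 nM, within an estimated range of 2500 nM to 30000 nM.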

Compound 3, half-maximal inhibitory concentration: > 10000 nM
Compound 3: only a limit was reported (the forecaster's own chance of this, stated with the estimate: 50%); at least 1.1-fold (0.04 log units) between middle value and limit.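

In this assay, cyclohexyl in place of methyl on this amine nitrogen gives an at least 1.8-fold higher number from compound 2 to compound 3 (0.25 log units; that floor lies within the scatter), a floor within the scatter. Within the data shown here, a six-membered non-aromatic ring here, like the phenyl of compound 1, thus yields only a limit, and methyl remains the only group on this nitrogen with a true number. The step between compound 1 and compound 3 cannot be read, and the true size of the rise stays unknown: the limit of > 10000 nM in this assay, at which 2 of the 3 values shown sit.

As far as these compounds go, whether an ethyl or isopropyl group on this nitrogen keeps a true number remains open. So does the point along such a series at which the number reaches the limit.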